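A Silyl Ether on the Primary Alcohol of Compound 1

This account rests on a few compounds, and the source may have more. Where it says the series, first, only, none or still open, it means among the compounds named here.

Compound 1 `C=C1CC[C@@H]2[C@](C)(CO)[C@H](OC(C)=O)CC[C@@]2(C)[C@@H]1C/C=C1/C(=O)OC[C@H]1O`: 26.4 uM
Compound 2 `C=C1CC[C@@H]2[C@](C)(CO)[C@H](OC(C)=O)CC[C@@]2(C)[C@@H]1C/C=C1/C(=O)OC[C@H]1OC(C)=O`: 11 uM
Compound 3 `C=C1CC[C@@H]2[C@](C)(COC(C)=O)[C@H](O)CC[C@@]2(C)[C@@H]1C/C=C1/C(=O)OC[C@H]1O`: 18.3 uM

In a functional assay on MCF7 cells (Homo sapiens) for cytotoxicity, read by sulforhodamine B assay (a higher number here means that more compound is needed for the effect, a lower number that less compound is needed), compound 1 stands highest of the three numbers; compound 3 sits within the scatter of it, while compound 2 lies beyond it, through a 2.4-fold lower number from compound 1 to compound 2 (0.38 log units; beyond the scatter). Compound 4 `C=C1CC[C@@H]2[C@](C)(CO[Si](C)(C)C(C)(C)C)[C@H](OC(C)=O)CC[C@@]2(C)[C@@H]1C/C=C1/C(=O)OC[C@H]1O` differs from compound 1 by a group of 7 heavy atoms (6 carbon, 1 silicon; no ring) in place of a hydrogen atom, on an oxygen on a saturated carbon. Going by the values given here, the only measured step that bears on this is the acetylation going from compound 1 to compound 2, which also replaces a hydrogen on an oxygen on a saturated carbon; it was modest. A silyl group of seven heavy atoms is a different addition, so the step from compound 1 to compound 4 is expected to be modest or within the scatter, at most a lowering of the number. Compound 4 is therefore estimated at 15 uM (range 6 uM to 40 uM), a step of a 1.8-fold lower number from compound 1 to compound 4 (0.25 log units; within the scatter).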

Compound 4, concentration for half-maximal effect: 9.79 uM
Compound 4: the middle estimate sits 1.5-fold (0.19 log units) above what was measured; low and high end bracket the measured number.
By their numbers in this assay, from the lowest: compounds 4, 2, 3 and 1 (each within the scatter of the next, the first and the last beyond it).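

In this assay, the silyl group on the oxygen on a saturated carbon gives a 2.7-fold lower number from compound 1 to compound 4 (0.43 log units; beyond the scatter). This shows that the free hydroxyl hydrogen at this position can be replaced by a group of 7 heavy atoms without the number rising, and the change is modest but beyond the scatter. Nothing available explains this step.

The compounds shown leave open how a methyl ether at this oxygen would compare. They also leave open whether a longer chain ending in an amine or a carboxylic acid would keep the lower number.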